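A few compounds are considered here, and "the series" means these few. Any claim that something is new, unique, unknown or untested is made for them only; others in the source may bear on it.

Compound 3 `Nc1ncnc2c1ncn2[C@@H]1CC[C@H](CO)C1` has been tested in a functional assay on MT4 cells (Homo sapiens) for cytotoxicity (a higher number here means that more compound is tolerated, a lower number that less compound is tolerated), and no exact number came out of that test. Compound 3 gives > 10000 nM, which is a limit and not a measured number. Its partner, compound 4 `Nc1ncnc2c1ncn2[C@H]1CC[C@@H](CO)C1`, has not yet been measured. The change is purely one of shape: the two compounds have the same atoms and bonds and differ only in configuration as drawn: 2 of 2 stereo elements differ (all stereocentres are inverted: mirror images); a stereocentre at a saturated ring carbon is drawn R in compound 3 and S in compound 4; a stereocentre at a saturated ring carbon is drawn S in compound 3 and R in compound 4. The two compounds have the same atoms and bonds and are mirror images, with all stereocentres inverted.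

For the measured compounds named here, only one measured step is of this kind, since compound 1 `Nc1ncnc2c1ncn2[C@H]1C=C[C@@H](CO)C1` and compound 2 `Nc1ncnc2c1ncn2[C@@H]1C=C[C@H](CO)C1` also form a mirror-image pair, as the fact that compounds 1 and 2 differ only in the configuration as drawn records. In this assay, compound 1 gives > 500000 nM, which is also a limit. Compound 2 gives > 100000 nM, again a limit. What remains is a step that the two limits leave unreadable from compound 1 to compound 2, so this pair offers no size and no direction for a mirror-image swap.

With no readable precedent, no particular direction is expected in this assay, and compound 4 will most likely be reported as a limit too. For compound 4 the estimated value is 30000 nM, with an expected range from 10000 nM to 200000 nM. This estimate means an expected step that the limit leaves unreadable from compound 3 to compound 4, a step that starts from a limit and therefore has no firm size.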

Compound 4, half-maximal cytotoxic concentration: > 125000 nM
Compound 4: only a limit was reported; the forecaster's own chance of this, stated with the estimate: 90%; at least 4.1-fold (0.61 log units) between middle value and limit.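

Compound 3 and compound 4 are mirror images, and this assay gives only a limit for each, so the step between them cannot be read. The compounds shown leave open at what concentration any of them becomes cytotoxic, and whether the two mirror-image forms in either pair differ at all.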